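Removing a Chain Methyl in a Platelet Inhibitor Series

The compounds below may be only part of what the source reports. "The series", "measured", "known", "first", "only" and "open" are said of these compounds alone.

Compound 1 `O=C(O)CCN1Cc2ccc(NC(=O)c3ccc(C4CCNCC4)cc3)cc2C1=O`: 9600 nM
Compound 2 `CC(CC(=O)O)N1Cc2ccc(NC(=O)c3cccc(N4CCNCC4)c3)cc2C1=O`: 62000 nM
Compound 3 `O=C(O)CCCN1Cc2ccc(NC(=O)c3ccc4c(c3)CNCC4)cc2C1=O`: 330000 nM

All three were measured in a functional assay on a cell-free system (Platelet, plasma, Homo sapiens) for inhibition; on this read-out lower numbers stand for stronger inhibition and higher numbers for weaker inhibition. Compound 2 stands second highest of the three numbers; compound 3 is its nearest neighbour and compound 1 its furthest, both gaps lying beyond the usual scatter. Compound 4 `O=C(O)CCN1Cc2ccc(NC(=O)c3cccc(N4CCNCC4)c3)cc2C1=O` differs from compound 2 by hydrogen in place of methyl on a saturated chain carbon bound to an amide-type nitrogen in a ring and a saturated chain carbon. For the measured compounds named here, no measured pair differs in only one place, so the size of such a step is not known from these data. For compound 4 a modest step toward stronger inhibition is expected, not clearly beyond the scatter, namely a 2.1-fold lower number from compound 2 to compound 4 (0.32 log units; beyond the scatter). Compound 4 is estimated at 30000 nM, with a range from 8000 nM to 110000 nM.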

Compound 4, half-maximal inhibitory concentration: 2700 nM
The estimate for compound 4 lay 11-fold (1.05 log units) above the measured number; the measured number lies below the stated range.
By their numbers in this assay, from the lowest: compound 4; then compound 1; then compound 2; then compound 3.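

Swapping methyl for hydrogen on the saturated chain carbon bound to an amide-type nitrogen in a ring and a saturated chain carbon gives a 23-fold lower number from compound 2 to compound 4 (1.36 log units; beyond the scatter) in this assay, the first measured change in one place in this set. The loss of a single carbon, with no ring, hydrogen-bond donor, hydrogen-bond acceptor or net charge involved, is therefore enough for a large step at this position. No evidence is available on what lies behind its size. Going by these compounds, whether an ethyl or hydroxyl group on this carbon would act like methyl remains open, as does whether removing methyl gives a similar step on the cores of compound 1 and compound 3.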